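A Trifluoromethylsulfonyl Group Enters the Core of Compound 1

The compounds below may be only part of what the source reports. "The series", "measured", "known", "first", "only" and "open" are said of these compounds alone.

Compound 1 `CN(C)CC[C@H](CSc1ccccc1)Nc1ccc(S(=O)(=O)NC(=O)c2ccc(N3CCN(Cc4ccccc4-c4ccc(Cl)cc4)CC3)cc2)cc1` was tested in an assay on isolated protein for displacement of a labelled ligand from Bcl2-associated agonist of cell death (Homo sapiens), read by fluorescence polarization (a lower number here means a stronger inhibitor, a higher number a weaker inhibitor), and gives 14 nM. Among the compounds with values here, it is the only compound here with a number of its own. Compound 2 `CN(C)CC[C@H](CSc1ccccc1)Nc1ccc(S(=O)(=O)NC(=O)c2ccc(N3CCN(CC4=C(c5ccc(Cl)cc5)CCC4)CC3)cc2)cc1[N+](=O)[O-]` reaches < 1 nM in this assay, which is a limit of the assay and not a number. Compound 3 `O=C(NS(=O)(=O)c1ccc(NCCSc2ccccc2)c([N+](=O)[O-])c1)c1ccc(N2CCN(Cc3ccccc3-c3ccc(Cl)cc3)CC2)cc1` likewise reaches < 1 nM, again a limit. Within the data shown here, two of the three values therefore sit at the limit of < 1 nM in this assay, at which 2 of the 3 values shown sit, and compound 1 stands apart as the one compound with a finite number.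

Compound 4 `CN(C)CC[C@H](CSc1ccccc1)Nc1ccc(S(=O)(=O)NC(=O)c2ccc(N3CCN(Cc4ccccc4-c4ccc(Cl)cc4)CC3)cc2)cc1S(=O)(=O)C(F)(F)F` has not been measured. It differs from compound 1 in one place: (trifluoromethyl)sulfonyl in place of hydrogen on an aromatic carbon. The new group sits on an aromatic carbon of a six-membered aromatic ring of carbon only, ortho to a large group and meta to a large group. Among the measured compounds shown here, no measured pair differing in one place is available, so the expectation rests on the spread of the three values alone. Stronger binding is expected because compound 2 already sits at the limit of < 1 nM. The step of a 9.3-fold lower number from compound 1 to compound 4 (0.97 log units; beyond the scatter) is the size expected, beyond the usual scatter. For compound 4 the estimated value in this assay is 1.5 nM, expected to fall between 0.3 nM and 7 nM.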

Compound 4, inhibition constant: < 1 nM
Compound 4 gave a limit, no number; the forecaster's own chance of this, stated with the estimate: 40%; middle value at least 1.5-fold (0.17 log units) from the limit.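

Within the data shown here, putting (trifluoromethyl)sulfonyl in place of hydrogen on this aromatic carbon, ortho to a large group and meta to a large group, is the first single change to the core of compound 1 that can be read directly, and in this assay it gives an at least 14-fold lower number from compound 1 to compound 4 (1.14 log units; beyond the scatter). This shows that the position accepts a group of 7 heavy atoms with no loss of binding, and that this one change on its own is enough to carry the core of compound 1 to a large step beyond the scatter. The value of compound 4 is a limit of the assay and not a number, which makes the step a minimum and leaves its true size unknown, and compound 4 now shares that ceiling with most of the series: the limit of < 1 nM in this assay, at which 3 of the 4 values shown sit.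

The compounds shown leave open whether the step depends on this particular group, or whether a methylsulfonyl, a nitrile, an amine or a carboxylic acid on the same aromatic carbon would give a step of similar size. They also leave open how much stronger compound 4 really is, since this assay gives it no finite number.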